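This account rests on a few compounds, and the source may have more. Where it says the series, first, only, none or still open, it means among the compounds named here.

Compound 3, whose structure is `CN(Cc1nc(C2CCN(Cc3ccccc3F)CC2)no1)c1ncc(C(=O)NO)cn1`, gives 44% in an assay on isolated protein for inhibition of protein deacetylase HDAC6 (Homo sapiens), read by fluorescence, with a stated time of 1 h, tested at 100 nM; on this read-out lower numbers stand for less inhibition and higher numbers for more inhibition at the one concentration tested (going by the name of the read-out). It stands second highest among the three measured numbers. Its nearest neighbour is compound 2, `Cc1cccc(CN2CCC(c3noc(CN(C)c4ncc(C(=O)NO)cn4)n3)CC2)c1`, which gives 54% in this assay; the step of a number 10 percentage points lower from compound 2 to compound 3 (within the scatter) is within the scatter. The furthest is compound 1, `Cc1ccc(CN2CCC(c3noc(COc4ccc(CCC(=O)NO)cc4)n3)CC2)cc1`, which gives 28% in this assay, a gap that lies beyond the scatter.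

Compound 4, with structure `CN(Cc1nc(C2CCN(Cc3ccccc3Cl)CC2)no1)c1ncc(C(=O)NO)cn1`, differs from compound 3 in one place: chloro in place of fluoro on an aromatic carbon. Among the measured compounds shown here, no measured step bears directly on an exchange of one halogen for another on this aromatic ring. For the measured compounds named here, the only measured step at this position of the shared core, from a 3-methylphenyl to a 2-fluorophenyl on the saturated chain carbon bound to the ring amine nitrogen, is a number 10 percentage points lower from compound 2 to compound 3 (within the scatter), which stayed within the scatter, so the data give no reason to expect a chloro in place of fluoro here to move the number far. Compound 4 is therefore expected to give about 47% in this assay, between 30% and 64%, which means an expected step of a number 3 percentage points higher from compound 3 to compound 4 (within the scatter), not beyond the scatter.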

Compound 4, a percentage reported as inhibition, at one concentration (the size of the read-out at that concentration, not a potency): 55%
Beside the measured number, compound 4's estimate is 8 percentage points below it; measured number inside the range.
By their numbers in this assay, from the lowest: compound 1; then compounds 3, 2 and 4 (each within the scatter of the next, the first and the last beyond it).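

Among the compounds shown here, this is the first change on this aromatic carbon that leaves the scatter: in this assay, chloro in place of fluoro gives a number 11 percentage points higher from compound 3 to compound 4 (beyond the scatter), a modest step, which shows that the choice of halogen on this ring can register at the one concentration tested. The exchange of the whole group reads differently, as the 2-chlorophenyl and 3-methylphenyl groups cannot be told apart, with a number 1 percentage points higher from compound 2 to compound 4 (within the scatter), so among these three compounds the 2-fluorophenyl compound is separated only from the 2-chlorophenyl compound. Nothing in the available data gives a reason for the halogen step.

On these data alone, whether a bromo, a methoxy or a trifluoromethyl on this same aromatic carbon would read with compound 3 or with compound 4 stays open, as does whether chloro on another carbon of the ring would give a similar number. Also open, as far as these compounds go, is whether the same exchange would give a comparable step on the core of compound 1, and, with readings at a single concentration, how far this step would carry over to potency.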